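A few compounds are considered here, and "the series" means these few. Any claim that something is new, unique, unknown or untested is made for them only; others in the source may bear on it.

Of the compounds shown here, three built on one shared core have been measured in a functional assay for agonist activity at Free fatty acid receptor 1 (Homo sapiens), read by FLIPR, in the presence of a further agent that is not named here; on this read-out lower numbers stand for an effect already at smaller amounts and higher numbers for an effect only at larger amounts of compound. Compound 1 `Cc1ccc(C)c(Oc2ccc(CC3SC(=O)NC3=O)cc2)c1` gives 238 nM. Compound 2 `Cc1ccccc1Oc1ccc(CC2SC(=O)NC2=O)cc1` gives 124 nM, and compound 3 `O=C1NC(=O)C(Cc2ccc(Oc3cccc(Cl)c3)cc2)S1` gives 318 nM. Compound 2 stands at the lowest of these three numbers, although the gap to compound 1 is within the scatter: a 1.9-fold lower number from compound 1 to compound 2 (0.28 log units; within the scatter), brought about by hydrogen in place of methyl on an aromatic carbon. The step of a 2.6-fold higher number from compound 2 to compound 3 (0.41 log units; beyond the scatter), brought about by 3-chlorophenyl in place of 2-methylphenyl on an oxygen on an aromatic ring, is modest but beyond the scatter.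

Compound 4 `Cc1cccc(Oc2ccc(CC3SC(=O)NC3=O)cc2)c1C` has not yet been measured. It differs from compound 2 by methyl in place of hydrogen on an aromatic carbon, the new group sitting on an aromatic carbon of a six-membered aromatic ring of carbon only, ortho to a methyl group and meta to a large group. Going by the values given here, the step that bears on this is the one from compound 1 to compound 2, where removing a methyl stayed within the scatter a 1.9-fold lower number from compound 1 to compound 2 (0.28 log units; within the scatter); putting a methyl back, at a different place, is therefore expected to move the number little. Compound 4 is expected to show roughly a 1.5-fold higher number from compound 2 to compound 4 (0.16 log units; within the scatter) in this assay, with an estimated 180 nM, ranging from 80 nM to 400 nM.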

Compound 4, half-maximal effective concentration: 334 nM
Estimate against measurement, compound 4: 1.9-fold (0.27 log units) below; low and high end bracket the measured number.
By their numbers in this assay, from the lowest: compounds 2, 1, 3 and 4 (each within the scatter of the next, the first and the last beyond it).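

On this ring, methyl in place of hydrogen on the aromatic carbon ortho to a methyl group is not a neutral change in this assay: it gives a 2.7-fold higher number from compound 2 to compound 4 (0.43 log units; beyond the scatter) and counts as a modest step. The earlier methyl step, a 1.9-fold lower number from compound 1 to compound 2 (0.28 log units; within the scatter) with the methyl at a different place on the ring, stayed within the scatter, so a single methyl does not read the same at every place on this ring. No measurement shown here explains this rise or the contrast between the two places.

The compounds shown leave open whether the higher number depends on the methyl group already present, since no compound carries a methyl at this carbon with hydrogen in place of that neighbouring group. They also leave open how another group on this same carbon, such as fluorine, methoxy or ethyl, would compare with the hydrogen of compound 2 and with the methyl of compound 4.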